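From Methoxycarbonyl to Nitro: Expecting a Small Step

The compounds below may be only part of what the source reports. "The series", "measured", "known", "first", "only" and "open" are said of these compounds alone.

Three related compounds have been tested in a functional assay on CCRF-CEM cells (Homo sapiens) for antiproliferative activity, read by trypan blue exclusion, with a stated time of 72 h; a lower number here means a stronger inhibitor, a higher number a weaker inhibitor. Compound 1 `Cc1ccc(C(=O)NC(N)=O)cc1NC(=O)C(C)Br` gives 3360 nM. Compound 2 `Cc1ccc(NC(=O)C(C)Br)cc1C(=O)NC(N)=O` gives > 20000 nM, which is a limit of the assay and not a number. Compound 3 `COC(=O)c1cc(NC(=O)C(C)Br)cc(C(=O)NC(N)=O)c1` gives 2700 nM, and this sits within the usual scatter of the number for compound 1, so the two stand level.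

The untested compound 4 `CC(Br)C(=O)Nc1cc(C(=O)NC(N)=O)cc([N+](=O)[O-])c1` keeps most of compound 3 and alters one group: nitro in place of methoxycarbonyl on an aromatic carbon, meta to a ((1-bromoethyl)carbonyl)amino group and meta to a carbamoylcarbamoyl group (nitro in place of methoxycarbonyl on an aromatic carbon).

Among the compounds with values here, no measured pair differs in just one place, so the data offer no direct guide to this swap. The nearest hint is that compound 1 at 3360 nM and compound 3 at 2700 nM differ in structure yet agree within the scatter. Compound 2 goes against that calm picture, so a larger loss cannot be ruled out. The expected change is small and probably within the scatter, an estimated 1.3-fold higher number from compound 3 to compound 4 (0.11 log units; within the scatter). In this assay, compound 4 is expected at 3500 nM, with an estimated range from 1200 nM to 10000 nM.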

Compound 4, half-maximal inhibitory concentration: 1580 nM
Compound 4: middle estimate off by 2.2-fold (0.35 log units), on the high side, and the stated range covers the measured number.
By their numbers in this assay, from the lowest: compounds 4, 3 and 1 (each within the scatter of the next, the first and the last beyond it). At a limit, above all of these: compound 2.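

The series now holds its first measured pair that differs in just one place. With nitro in place of methoxycarbonyl, on the aromatic carbon meta to a ((1-bromoethyl)carbonyl)amino group and meta to a carbamoylcarbamoyl group, this assay shows a 1.7-fold lower number from compound 3 to compound 4 (0.23 log units; within the scatter). The two groups therefore stand level at this position, so this carbon takes either one without a real change in the read-out, even though methoxycarbonyl has 4 heavy atoms and nitro has 3, and each counts 2 hydrogen-bond acceptors and no donors. Nothing measured here bears on a cause for this result.

What the compounds shown leave open is how far this tolerance reaches, since two groups at one position cannot show whether a carboxylic acid, an amine or a longer ester chain would also hold the read-out level there. They also leave open whether the same swap of methoxycarbonyl for nitro would stand level at another carbon of the ring, or with a different arrangement of the other two groups.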